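Replacing the anilino group on the shared core with 4-methylpiperazin-1-yl

A few compounds are considered here, and "the series" means these few. Any claim that something is new, unique, unknown or untested is made for them only; others in the source may bear on it.

Measured compounds in a functional assay on GOTO cells (Homo sapiens) for cytotoxicity, read by MTT assay, with a stated time of 3 days; on this read-out higher numbers stand for weaker inhibition and lower numbers for stronger inhibition:
Compound 1, `N#Cc1c(Nc2ccccc2)nc(SCc2nc3ccccc3[nH]2)nc1-c1ccccc1`, gives 6.41 nM.
Compound 2, `N#Cc1c(Nc2nccs2)nc(SCc2nc3ccccc3[nH]2)nc1-c1ccccc1`, gives 5.1 nM.
Compound 3, `N#Cc1c(NC(N)=O)nc(SCc2nc3ccccc3[nH]2)nc1-c1ccccc1`, gives 11.3 nM.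

Compound 1 stands second highest of the three numbers. Its nearest neighbour is compound 2, a 1.3-fold lower number from compound 1 to compound 2 (0.10 log units; within the scatter), and its furthest is compound 3, a 1.8-fold higher number from compound 1 to compound 3 (0.25 log units; within the scatter); only a 2.2-fold higher number from compound 2 to compound 3 (0.35 log units; beyond the scatter) reaches beyond the scatter. Compound 4, `CN1CCN(c2nc(SCc3nc4ccccc4[nH]3)nc(-c3ccccc3)c2C#N)CC1`, differs from compound 1 by 4-methylpiperazin-1-yl in place of anilino on an aromatic carbon. The measured steps all exchange the group carried by that nitrogen; none replaces the anilino group itself with a ring of this kind, so they bear on the new change only loosely. Since those steps were small, a modest step is expected, a 1.9-fold higher number from compound 1 to compound 4 (0.27 log units; within the scatter), with compound 4 estimated at 12 nM within a range of 4 nM to 40 nM.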

Compound 4, half-maximal inhibitory concentration: 3.37 nM
Estimate against measurement, compound 4: 3.6-fold (0.55 log units) above, and the stated range ends above it.
By their numbers in this assay, from the lowest: compounds 4, 2, 1 and 3 (each within the scatter of the next, the first and the last beyond it).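

In this assay, this position on the shared core accepts 4-methylpiperazin-1-yl, a six-membered non-aromatic ring with 0 hydrogen-bond donors, in place of the nitrogen-linked groups: the number stays within the scatter of anilino (a 1.9-fold lower number from compound 1 to compound 4 (0.28 log units; within the scatter)) and of (1,3-thiazol-2-yl)amino (a 1.5-fold lower number from compound 2 to compound 4 (0.18 log units; within the scatter)). Only against ureido does the change stand beyond the scatter (a 3.4-fold lower number from compound 3 to compound 4 (0.53 log units; beyond the scatter)). Nothing available explains these numbers. Still open, from the compounds shown here alone, is whether morpholin-4-yl, piperazin-1-yl without its methyl, or an open-chain dimethylamino group would behave the same way.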